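The source may hold more compounds than are shown below. What is called first, only, known or untested is meant among the compounds shown, and "the series" means these compounds.

Compounds measured in a functional assay on HEK293 cells for antagonist activity at Voltage-dependent L-type calcium channel subunit alpha-1D (Rattus norvegicus), read by FLIPR; on this read-out higher numbers stand for weaker inhibition and lower numbers for stronger inhibition:
compound 1 `COC(=O)C1=C(C)NC(C)=C(C(=O)OCCCl)C1c1cccc([N+](=O)[O-])c1` gives 22 nM;
compound 2 `C=C(C)C(=O)OCCOC(=O)C1=C(C)NC(C)=C(C(=O)OCC)C1c1cccc([N+](=O)[O-])c1` gives 10 nM;
compound 3 `CCOC(=O)C1=C(C)NC(C)=C(C(=O)OC=O)C1c1cccc([N+](=O)[O-])c1` gives 13900 nM.

Compound 1 stands second highest of the three numbers in this assay; compound 2 sits somewhat lower at 10 nM, and compound 3 stands far higher in the order, giving 13900 nM. Compound 4 `COC(=O)C1=C(C)NC(C)=C(C(=O)OC2Cc3ccccc3C2)C1c1cccc([N+](=O)[O-])c1` differs from compound 1 by 2,3-dihydro-1H-inden-2-yl in place of 2-chloroethyl on an oxygen next to a carbonyl group. For the measured compounds named here, the single measured step, a 1400-fold higher number from compound 2 to compound 3 (3.14 log units; beyond the scatter), concerns a different exchange at that oxygen and does not bear on this one; no measured pair tests a ring in this place. With nothing to indicate otherwise, compound 4 is expected to stay close to compound 1, giving a step of a 1.4-fold higher number from compound 1 to compound 4 (0.13 log units; within the scatter). The estimate for compound 4 in this assay is 30 nM, with a range of 8 nM to 120 nM.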

Compound 4, half-maximal inhibitory concentration: 43 nM
Compound 4: middle estimate off by 1.4-fold (0.16 log units), on the low side; measured number inside the range.
By their numbers in this assay, from the lowest: compound 2; then compounds 1 and 4 (each within the scatter of the next); then compound 3.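

In this assay the exchange of 2-chloroethyl for 2,3-dihydro-1H-inden-2-yl on an oxygen next to a carbonyl group gives a 2.0-fold higher number from compound 1 to compound 4 (0.29 log units; within the scatter) and so shows that this oxygen can carry a carbocyclic group with no step beyond the scatter. The earlier compounds shown here held only open chains and formyl here. No measurement at hand offers a reason for this result. Still open, from the compounds shown here alone, is whether a chain ending in an amine or a carboxylic acid on this oxygen would stay within the scatter of compound 1.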